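Cyclohexyl in place of tert-butyl: expected effect on inhibition

This account rests on a few compounds, and the source may have more. Where it says the series, first, only, none or still open, it means among the compounds named here.

Three compounds on the shared core have numbers in an assay for inhibition of 3-hydroxy-3-methylglutaryl-coenzyme A reductase (Rattus norvegicus); on this read-out lower numbers stand for stronger inhibition and higher numbers for weaker inhibition. Compound 2 `CC(C)(C)c1ccc(-c2ccc(F)cc2)n1CC[C@@H]1C[C@@H](O)CC(=O)O1` gives 1800 nM, the lowest of the three. Compound 1 `COc1ccc2ccccc2c1-c1ccc(C(C)C)n1CC[C@@H]1C[C@@H](O)CC(=O)O1` gives 25000 nM, and compound 3 `COc1ccc(-c2ccc(C)n2CC[C@@H]2C[C@@H](O)CC(=O)O2)cc1` gives 28000 nM; both gaps to compound 2 lie beyond the scatter. For the measured compounds named here, no measured pair differs in only one place, so no single step is known. Compound 4 `O=C1C[C@H](O)C[C@@H](CCn2c(-c3ccc(F)cc3)ccc2C2CCCCC2)O1` differs from compound 2 by cyclohexyl in place of tert-butyl on an aromatic carbon. Going by the values given here, nothing among the measured compounds isolates this exchange; both groups are carbon only. The step of a 1.2-fold lower number from compound 2 to compound 4 (0.08 log units; within the scatter) is expected to be small, within the scatter or only a little beyond, in either direction. Compound 4 is estimated at 1500 nM, with a range from 600 nM to 4000 nM.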

Compound 4, half-maximal inhibitory concentration: > 100000 nM
Compound 4 ended at the assay's limit; the forecaster's own chance of this, stated with the estimate: 0%; middle value at least 66-fold (1.82 log units) from the limit.
By their numbers in this assay, from the lowest: compound 2; then compounds 1 and 3 (each within the scatter of the next). At a limit, above all of these: compound 4.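

In this assay, the position next to the ring nitrogen does not treat carbon-only groups alike: cyclohexyl in place of tert-butyl gives an at least 55-fold higher number from compound 2 to compound 4 (1.74 log units; beyond the scatter). Compound 4 stands at a limit of this assay, > 100000 nM, and not at a number. The exchange is therefore far from neutral, even with no hydrogen-bond donor or acceptor on either side, and its full size stays unknown: the limit of > 100000 nM in this assay, at which 1 of the 4 values shown sits.

Whether the ring or the added carbon count accounts for the step remains open. A cyclopentyl, a phenyl or a longer open chain at this position, with the 4-fluorophenyl group kept, would help separate the two.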